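Chloro for methoxy on two related quinoline cores

The source may report more compounds than this note shows. Statements on the series, on what has been measured and on what is new or still open speak of the compounds shown alone.

Compound 1 `COc1ccc2c(=O)c(Cc3ccccc3)c(C)[nH]c2c1` and compound 2 `Cc1[nH]c2cc(Cl)ccc2c(=O)c1Cc1ccccc1` share one core. In a physicochemical assay for lipophilicity, at pH 7.4 (a lower number here means a more polar compound, a higher number a more lipophilic compound), compound 1 gives 2.52 and compound 2 gives 2.69. The two differ in a single place, (chloro in place of methoxy on an aromatic carbon), and the step of a number 0.17 log units higher from compound 1 to compound 2 (within the scatter) is within the scatter of this assay.

Compound 3 `COc1ccc2nc(C)c(Cc3ccccc3)c(OC)c2c1` is built on a different core; the difference between the two cores is not broken down here. In this assay compound 3 gives 4.2, the highest of the three numbers, standing beyond the scatter above both compound 1 and compound 2.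

Compound 4 `COc1c(Cc2ccccc2)c(C)nc2ccc(Cl)cc12` has not yet been measured. It differs from compound 3 in exactly the same way that compound 2 differs from compound 1, namely (chloro in place of methoxy on an aromatic carbon), with the same surroundings at the place of the change. On the core of compound 1 this exchange moved the number only slightly, so the expected step is a number 0.17 log units higher from compound 3 to compound 4 (within the scatter), resting on the measured step of a number 0.17 log units higher from compound 1 to compound 2 (within the scatter). Accordingly compound 4 is estimated at 4.37, between 4 and 4.8.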

Compound 4, distribution coefficient: 4.93
Estimate against measurement, compound 4: 0.56 log units below; measured number above the stated range.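

Among these compounds, the same exchange of chloro for methoxy on an aromatic carbon, with the same surroundings at the place of the change, gives in this assay a number 0.73 log units higher from compound 3 to compound 4 (beyond the scatter), whereas on the core of compound 1 it gave a number 0.17 log units higher from compound 1 to compound 2 (within the scatter), so the step measured on one core did not carry over in size to the other, although the number rose on both and only the step on the core of compound 3 lies beyond the scatter. This rests on a single pair of compounds per core, and it does not show how the step would behave on any further core or whether the two cores would keep this contrast with other groups. Nothing given here explains why the exchange reads differently on the two cores.

The compounds shown leave open how an amine or a carboxylic acid would read on that same aromatic carbon on each core. They also leave open whether a longer chain in place of the methoxy would give steps that agree between the two cores.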